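A few compounds are considered here, and "the series" means these few. Any claim that something is new, unique, unknown or untested is made for them only; others in the source may bear on it.

Working notes on the series in a functional assay on KYSE-450 cells (Homo sapiens) for inhibition, read by MTT assay, with a stated time of 48 h; on this read-out lower numbers stand for stronger inhibition and higher numbers for weaker inhibition. Three compounds carry numbers. Compound 1 `C/C=C/C(=O)N(Cc1cccc(O)c1)c1cc(OC)c(OC)c(OC)c1` gives 14700 nM; compound 2 `C/C=C/C(=O)N(Cc1cc(OC)c(OC)c(OC)c1)c1ccc(OC)c(O)c1` gives 9160 nM; compound 3 `C/C=C/C(=O)N(Cc1ccc(OC)c(C)c1)c1cc(OC)c(OC)c(OC)c1` gives 32900 nM. Compound 2 stands at the lowest of the three numbers; its gap to compound 1 is within the scatter, so no order between those two is claimed, while its gap to compound 3 is beyond the scatter. Among the measured compounds shown here, the single one-place step available, a 2.2-fold higher number from compound 1 to compound 3 (0.35 log units; beyond the scatter), concerns the group on the saturated chain carbon bound to the amide-type nitrogen and was modest.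

Compound 4 `COc1ccc(N(Cc2cc(OC)c(OC)c(OC)c2)C(=O)CCl)cc1O` is next: chloromethyl in place of prop-1-en-1-yl on a carbonyl carbon. For the measured compounds named here, this change sits on the carbonyl carbon, a place no measured step in the set touches; the step from compound 1 to compound 3 bears only indirectly, as a sign that single swaps here have so far moved this assay modestly. No direction can be read from the data for the carbonyl substituent, so no step beyond the scatter is expected, and the range is kept wide. The estimate for compound 4 is 7000 nM, with a range from 1500 nM to 30000 nM. The expected step of a 1.3-fold lower number from compound 2 to compound 4 (0.12 log units; within the scatter) is thus small relative to the uncertainty.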

Compound 4, half-maximal inhibitory concentration: 29800 nM
Beside the measured number, compound 4's estimate is 4.3-fold (0.63 log units) below it, and the stated range covers the measured number.
By their numbers in this assay, from the lowest: compounds 2 and 1 (each within the scatter of the next); then compounds 4 and 3 (each within the scatter of the next).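

In this assay, the carbonyl carbon now has a measured step of its own: a 3.3-fold higher number from compound 2 to compound 4 (0.51 log units; beyond the scatter), for chloromethyl in place of prop-1-en-1-yl. Among the compounds shown here, until now the only one-place step concerned the group on the saturated chain carbon bound to the amide-type nitrogen, so this shows that the substituent on the carbonyl carbon can also move the number beyond the scatter, with prop-1-en-1-yl giving the lower number in this one pair. No measurement in hand accounts for the step, which stands here as an observation for a single pair on the core of compound 2.

The compounds shown leave open whether the lower number is particular to prop-1-en-1-yl or would also come with a plain methyl, a saturated propyl chain or a dimethylamino-bearing chain on the carbonyl carbon. Also open, on these data alone, is whether the same swap would give a step of similar size and direction on the core of compound 1 or compound 3.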